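Replacing Isobutyl with (tert-Butyl)amino on the Sulfonyl Sulfur

A few compounds are considered here, and "the series" means these few. Any claim that something is new, unique, unknown or untested is made for them only; others in the source may bear on it.

Three compounds share one core and differ only in the group carried on a sulfonyl sulfur. In an assay on CHO cells for displacement of a labelled ligand from prostaglandin D2 receptor 2 (Homo sapiens), read by scintillation counting (a lower number here means a stronger inhibitor, a higher number a weaker inhibitor), compound 1 `Cc1ccc(S(=O)(=O)CCO)cc1C#Cc1cc(Cl)ccc1OCC(=O)O` gives 19 nM. Compound 2 `COCCNS(=O)(=O)c1ccc(C)c(C#Cc2cc(Cl)ccc2OCC(=O)O)c1` gives 3.6 nM, and compound 3 `Cc1ccc(S(=O)(=O)CC(C)C)cc1C#Cc1cc(Cl)ccc1OCC(=O)O` gives 3 nM. Compound 3 carries the lowest number of the three, but its gap to compound 2 is within the scatter, so the two cannot be told apart; only compound 1 stands clearly away, with a 5.3-fold lower number from compound 1 to compound 2 (0.72 log units; beyond the scatter) and a 6.3-fold lower number from compound 1 to compound 3 (0.80 log units; beyond the scatter) marking the two steps out from it.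

Compound 4 `Cc1ccc(S(=O)(=O)NC(C)(C)C)cc1C#Cc1cc(Cl)ccc1OCC(=O)O` has not been measured. It differs from compound 3 in one place: (tert-butyl)amino in place of isobutyl on a sulfonyl sulfur. Among the measured compounds shown here, the measured step that most resembles it is the one where a group bearing an amino nitrogen on the same sulfur was exchanged for an alkyl group, and the number barely moved: a 1.2-fold lower number from compound 2 to compound 3 (0.08 log units; within the scatter). For the measured compounds named here, the present change runs the other way, putting an amino nitrogen back onto the sulfur, and nothing among the measured compounds points to a larger shift. Compound 4 is therefore expected to stay close to the number of compound 3. The expected step is a 1.3-fold higher number from compound 3 to compound 4 (0.12 log units; within the scatter). The estimate for compound 4 in this assay is 4 nM, within a range of 1.5 nM to 12 nM.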

Compound 4, inhibition constant: 5 nM
Compound 4: the middle estimate sits 1.3-fold (0.10 log units) below what was measured; measured number inside the range.
By their numbers in this assay, from the lowest: compounds 3, 2 and 4 (each within the scatter of the next); then compound 1.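

Compound 4 adds a sulfonamide bearing a bulkier group on its nitrogen, and the result shows that this position accepts more than the two kinds of group seen earlier. In this assay there is a 1.7-fold higher number from compound 3 to compound 4 (0.22 log units; within the scatter) when (tert-butyl)amino, with its one hydrogen-bond donor, takes the place of isobutyl, so the two groups cannot be told apart on this sulfonyl sulfur. The same holds on the sulfonamide nitrogen, with a 1.4-fold higher number from compound 2 to compound 4 (0.14 log units; within the scatter) for tert-butyl in place of 2-methoxyethyl, while the step from the 2-hydroxyethyl group remains real but modest, at a 3.8-fold lower number from compound 1 to compound 4 (0.58 log units; beyond the scatter) and so compound 1 is still the one that goes against the otherwise flat picture.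

Nothing shown here accounts for the gap between compound 1 and the other three compounds. Also open, going by these compounds, is whether a bare amino group or a morpholine ring on the sulfonyl sulfur would fall with compound 2, compound 3 and compound 4, or with compound 1.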